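The source may hold more compounds than are shown below. What is called first, only, known or untested is meant among the compounds shown, and "the series" means these compounds.

Measured in an ADME assay on MT4 cells (Homo sapiens) for cytotoxicity, read by MTT assay (a higher number here means that more compound is tolerated, a lower number that less compound is tolerated), where every value is a limit:

- Compound 1 `Cc1cn([C@H]2C=CC(CO)(CO)S2)c(=O)[nH]c1=O`: > 100000 nM
- Compound 2 `COC(=O)[C@@]1(CO)C=C[C@H](n2cc(C)c(=O)[nH]c2=O)S1`: > 100000 nM
- Compound 3 `Cc1cn([C@H]2C=C[C@](CO)(C(N)=O)S2)c(=O)[nH]c1=O`: > 100000 nM

Compound 3 gives > 100000 nM, which is a limit and not a number. It therefore has no exact place on the scale. The whole set looks the same, with the limit of > 100000 nM in this assay, at which 3 of the 3 values shown sit.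

Compound 4 `C=C[C@@]1(CO)C=C[C@H](n2cc(C)c(=O)[nH]c2=O)S1` carries vinyl in place of carbamoyl on a saturated ring carbon. For the measured compounds named here, the only measured step is a step that the two limits leave unreadable from compound 2 to compound 3, so it offers no size to carry over. Going by the values given here, no measured compound carries a vinyl group, and the three limits give no sign of any change in this assay. Among the compounds with values here, no step of readable size or direction is therefore expected, and the estimated step is a number no higher from compound 3 to compound 4 (the limit leaves the size open). For compound 4 the expected value is 100000 nM, with an estimated range of 50000 nM to 100000 nM. The most likely outcome is another report of a limit rather than a number.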

Compound 4, half-maximal cytotoxic concentration: > 100000 nM
Compound 4 ended at the assay's limit; the forecaster's own chance of this, stated with the estimate: 80%; the middle value sits exactly at the limit.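

In this assay compound 4 gives > 100000 nM, which is a limit and not a number, so its steps from compound 2 and compound 3 cannot be read. The compounds shown leave open what concentration of any of them the cells fail to tolerate, and whether swapping these groups changes it.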